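This account rests on a few compounds, and the source may have more. Where it says the series, first, only, none or still open, it means among the compounds named here.

Measured so far:
- compound 1 `CC(C)(C)OC(=O)NCCNC(=O)CN1CN(c2ccccc2)C2(CCN(C(=O)c3ccc(C4CCCCC4)cc3)CC2)C1=O`: 5500 nM
- compound 2 `CC(C)(C)c1ccc(C(=O)N2CCC3(CC2)C(=O)N(CC(=O)NCN)CN3c2ccccc2)cc1`: 26500 nM

In an assay on HEK293 cells for displacement of a labelled ligand from NPC1-like intracellular cholesterol transporter 1 (Homo sapiens) (on this read-out higher numbers stand for weaker inhibition and lower numbers for stronger inhibition), compound 2 gives the highest of the two numbers; compound 1 gives the lower one, and that gap lies beyond the scatter. Compound 3 `CC(C)(C)c1ccc(C(=O)N2CCC3(CC2)C(=O)N(CC(=O)NCNS(C)(=O)=O)CN3c2ccccc2)cc1` is not yet measured. It differs from compound 2 only as follows: methylsulfonyl in place of hydrogen on an amine nitrogen. Within the data shown here, no measured pair shows this change, so its effect is unknown. A small step is expected, a 1.3-fold lower number from compound 2 to compound 3 (0.12 log units; within the scatter), not clearly beyond the scatter in either direction. Compound 3 is therefore estimated at 20000 nM, with a likely range from 6000 nM to 70000 nM.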

Compound 3, half-maximal inhibitory concentration: 3200 nM
The estimate for compound 3 lay 6.3-fold (0.80 log units) above the measured number; the measured number lies below the stated range.
By their numbers in this assay, from the lowest: compounds 3 and 1 (each within the scatter of the next); then compound 2.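

In this assay, among these compounds, methylsulfonyl in place of hydrogen on an amine nitrogen gives an 8.3-fold lower number from compound 2 to compound 3 (0.92 log units; beyond the scatter), the first single-place step. This amine nitrogen is thus a position where substitution moves the read-out, and a free amino group is not required for the inhibition seen here. No measurement at hand accounts for the step.

Open, from the compounds shown here alone, is whether acetyl or ethylsulfonyl on the same nitrogen would give a similar number. Also open, going by these compounds, is whether a longer chain carrying the methylsulfonyl would retain the step.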